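Replacing 6-methoxypyridin-3-yl with 4-ethoxy-3-fluorophenyl

The compounds below may be only part of what the source reports. "The series", "measured", "known", "first", "only" and "open" are said of these compounds alone.

Measured in a functional assay on HeLa cells (Homo sapiens) for antiproliferative activity, read by MTT assay, with a stated time of 48 h; a lower number here means a stronger inhibitor, a higher number a weaker inhibitor:
- compound 1 `COc1ccc(-c2cc3c(cn2)[nH]c(=O)n3-c2cc(OC)c(OC)c(OC)c2)cc1F`: 2210 nM
- compound 2 `COc1ccc(-c2cc3c(cn2)[nH]c(=O)n3-c2cc(OC)c(OC)c(OC)c2)cc1O`: 490 nM
- compound 3 `COc1ccc(-c2cc3c(cn2)[nH]c(=O)n3-c2cc(OC)c(OC)c(OC)c2)cn1`: 870 nM

Compound 3 gives 870 nM, the second highest of the three numbers. The measured steps that reach it are a 1.8-fold higher number from compound 2 to compound 3 (0.25 log units; within the scatter) and a 2.5-fold lower number from compound 1 to compound 3 (0.40 log units; beyond the scatter).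

The next compound is compound 4 `CCOc1ccc(-c2cc3c(cn2)[nH]c(=O)n3-c2cc(OC)c(OC)c(OC)c2)cc1F`. Its structural change is 4-ethoxy-3-fluorophenyl in place of 6-methoxypyridin-3-yl on an aromatic carbon.

The closest measured comparison is compound 1, whose 3-fluoro-4-methoxyphenyl group also carries the fluoro and which gives 2210 nM. The measured 2.5-fold lower number from compound 1 to compound 3 (0.40 log units; beyond the scatter) therefore bears most directly, read in reverse. Compound 2 bears less directly, although a 4.5-fold lower number from compound 1 to compound 2 (0.65 log units; beyond the scatter) shows that a single exchange on this phenyl group can move the number beyond the scatter. For the measured compounds named here, no measured pair compares ethoxy with methoxy, so that part of the change remains open and widens the range.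

A modest step towards a higher number is therefore expected in this assay. The expected change is a 2.8-fold higher number from compound 3 to compound 4 (0.44 log units; beyond the scatter). For compound 4 the estimated value is 2400 nM, with an expected range of 900 nM to 6000 nM.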

Compound 4, half-maximal inhibitory concentration: 2870 nM
Estimate against measurement, compound 4: 1.2-fold (0.08 log units) below; measured number inside the range.
By their numbers in this assay, from the lowest: compounds 2 and 3 (each within the scatter of the next); then compounds 1 and 4 (each within the scatter of the next).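

In this assay the 4-ethoxy-3-fluorophenyl group gives a 3.3-fold higher number from compound 3 to compound 4 (0.52 log units; beyond the scatter) when it replaces 6-methoxypyridin-3-yl and a 5.9-fold higher number from compound 2 to compound 4 (0.77 log units; beyond the scatter) when it replaces 3-hydroxy-4-methoxyphenyl, so at this position it stands apart from both of those groups. The comparison that was missing until now, ethoxy against methoxy with the fluoro kept, gives a 1.3-fold higher number from compound 1 to compound 4 (0.11 log units; within the scatter) and so does not separate the two ethers; with these four compounds, the two that carry the fluoro fall together, and both lie beyond the scatter from compound 2 and compound 3. Nothing shown here gives a reason for any of these steps.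

The compounds shown leave open whether the ether chain can grow further without a change in the number, as with a propoxy or a longer alkoxy chain, and whether the ethoxy group would behave the same way alongside a hydroxy group instead of the fluoro. For the compounds shown here, they also leave open how an amine or a chloro group in place of that fluoro would read, since only one exchange at that spot, hydroxy for fluoro, can be followed here.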